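Adding a Methoxy Group to the Anilino Ring

The source may report more compounds than this note shows. Statements on the series, on what has been measured and on what is new or still open speak of the compounds shown alone.

Of the compounds shown here, three built on one shared core have been measured in a functional assay, with a stated time of 150 min, tested at 35 ug/mL; a higher number here means a stronger effect of the compound at the concentration tested, a lower number a weaker effect. Compound 1 `COC(=O)c1c(Nc2ccccc2)sc(C(=O)c2ccc(OC)cc2)c1C` gives 63% in this assay. Compound 2 `COC(=O)c1c(Nc2ccc(OC)cc2)sc(C(=O)c2ccc(OC)cc2)c1C` gives 25.1% in this assay. Compound 3 `COc1ccc(C(=O)c2sc(Nc3ccccc3)c(C(=O)O)c2C)cc1` gives 61.2% in this assay, the second highest of the three numbers; the gap to compound 1 lies within the scatter, while compound 2 stands far lower.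

Two steps between measured compounds are known. The step of a number 1.8 percentage points lower from compound 1 to compound 3 (within the scatter) stayed within the scatter. The step of a number 37.9 percentage points lower from compound 1 to compound 2 (beyond the scatter), by contrast, was a large fall.

Compound 4 `COc1ccc(Nc2sc(C(=O)c3ccc(OC)cc3)c(C)c2C(=O)O)cc1` has not yet been measured. It differs from compound 3 in one place: methoxy in place of hydrogen on an aromatic carbon. For the measured compounds named here, this is the same change in the same position as the one behind the step of a number 37.9 percentage points lower from compound 1 to compound 2 (beyond the scatter), and that step is the only one that bears on the question. A fall of similar size in this assay is therefore expected, with some uncertainty because that evidence rests on a single pair.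

Compound 4 is expected to give about 25% in this assay, within a range from 10% to 45%. The expected change is a number 36.2 percentage points lower from compound 3 to compound 4 (beyond the scatter).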

Compound 4, a percentage reported as activity, at one concentration (the size of the read-out at that concentration, not a potency): 51%
Compound 4: middle estimate off by 26 percentage points, on the low side; measured number outside the range, above it.
By their numbers in this assay, from the lowest: compound 2; then compound 4; then compounds 3 and 1 (each within the scatter of the next).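

Compound 4 shows that a methoxy group para to a large group does not carry a fixed penalty in this assay: on the carboxylic acid core the change from anilino to (4-methoxyphenyl)amino still lowers the read-out, but only as a number 10.2 percentage points lower from compound 3 to compound 4 (beyond the scatter), and its size depends on what sits at the other changed place: the same change on two cores in this assay, a number 37.9 percentage points lower (beyond the scatter) from compound 1 to compound 2 and a number 10.2 percentage points lower (beyond the scatter) from compound 3 to compound 4, 27.7 percentage points apart, beyond the scatter of two such steps The same holds in reverse for the swap of the methyl ester for the carboxylic acid, which made no readable difference without the methoxy group but gives a number 25.9 percentage points higher from compound 2 to compound 4 (beyond the scatter) when the methoxy group is present: the same change on two cores in this assay, a number 1.8 percentage points lower (within the scatter) from compound 1 to compound 3 and a number 25.9 percentage points higher (beyond the scatter) from compound 2 to compound 4, 27.7 percentage points apart, beyond the scatter of two such steps Across these four compounds, then, the two changes do not simply add up, so the effect of one can be read only with the other place fixed.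

The compounds shown leave open why the two places are linked, and whether the link belongs to methoxy alone. An amine or a longer chain such as ethoxy on the same aromatic carbon, with either the methyl ester or the carboxylic acid, would show whether other groups follow the same pattern.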